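This account rests on a few compounds, and the source may have more. Where it says the series, first, only, none or still open, it means among the compounds named here.

Measured so far in a functional assay on NALM-6 cells (Homo sapiens) for cytotoxicity, with a stated time of 72 h; on this read-out higher numbers stand for an effect only at larger amounts of compound and lower numbers for an effect already at smaller amounts:
- Compound 1 `C=C[C@@](C)(/C=C/c1ccc(O)c(CO)c1)CCC=C(C)C`: 16400 nM
- Compound 2 `C=C[C@@](C)(/C=C/c1ccc(O)c(/C=C/C#N)c1)CCC=C(C)C`: > 43400 nM (a limit, not a number)
- Compound 3 `C=C[C@@](C)(/C=C/c1ccc(O)c(/C=C/C(=O)O)c1)CCC=C(C)C`: > 43400 nM (a limit, not a number)

Compound 3 has no exact value, only the limit (the limit of > 43400 nM in this assay, at which 2 of the 3 values shown sit). Compound 4 `C=C[C@@](C)(/C=C/c1ccc(O)c(/C=C/C(N)=O)c1)CCC=C(C)C` differs from it as follows: amino in place of hydroxy on a carbonyl carbon. This is amino in place of hydroxy on a carbonyl carbon, which turns 2-carboxyethenyl into 2-carbamoylethenyl.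

Among the measured compounds shown here, three measured steps bear on this change. The first two are an at least 2.6-fold higher number from compound 1 to compound 2 (0.42 log units; beyond the scatter) and an at least 2.6-fold higher number from compound 1 to compound 3 (0.42 log units; beyond the scatter). Each replaces the hydroxymethyl of compound 1 with a substituted ethenyl group, and compound 4 keeps such a group. The third, a step that the two limits leave unreadable from compound 2 to compound 3, alters only the end of that chain, as the new change does, but it gives no size to build on. A step beyond the scatter is therefore not expected, and a return towards compound 1 has no support. The expected change is an at least 1.0-fold lower number from compound 3 to compound 4 (0.03 log units; that floor lies within the scatter). For compound 4, the estimated value is 40000 nM, with an expected range from 18000 nM to 80000 nM.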

Compound 4, half-maximal effective concentration: > 43400 nM
Compound 4: no number, only a limit; the forecaster's own chance of this, stated with the estimate: 60%; at least 1.0-fold (0.03 log units) between middle value and limit.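

Putting 2-carbamoylethenyl in place of the hydroxymethyl gives an at least 2.6-fold higher number from compound 1 to compound 4 (0.42 log units; beyond the scatter), so a third substituted ethenyl group at this place goes with a weaker effect in this assay. Compound 4 has only a limit, not a number, and the nitrile, carboxy and carbamoyl chain ends all stop at the same one: the limit of > 43400 nM in this assay, at which 3 of the 4 values shown sit. The steps among compound 2, compound 3 and compound 4 cannot be read, so these three chain ends cannot be ranked, and the change from hydroxy to amino has no measurable size.

Going by these compounds, it remains open whether the double bond or the chain end matters more, which a saturated 2-carbamoylethyl chain could test. Among the compounds shown here, it is also open whether a smaller group such as aminomethyl would match or improve on compound 1, the only compound here with an exact value, at 16400 nM.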